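Replacing a Fluorophenyl with a Sulfamoyl-Bearing Phenyl

The source may report more compounds than this note shows. Statements on the series, on what has been measured and on what is new or still open speak of the compounds shown alone.

Measured in a functional assay on MCF7 cells (Homo sapiens) for antiproliferative activity, read by MTT assay, with a stated time of 48 h; a lower number here means a stronger inhibitor, a higher number a weaker inhibitor:
- Compound 1 `Cc1c(Cc2ccccc2)c(=O)oc2cc(OCCOc3no[n+]([O-])c3S(=O)(=O)c3ccccc3)ccc12`: 2350 nM
- Compound 2 `Cc1c(Cc2ccc(F)cc2)c(=O)oc2cc(OCCOc3no[n+]([O-])c3S(=O)(=O)c3ccccc3)ccc12`: 2850 nM

For the measured compounds named here, compound 2 cannot be told apart from compound 1, the only other measured compound, with a 1.2-fold higher number from compound 1 to compound 2 (0.08 log units; within the scatter). Compound 3 `CNS(=O)(=O)Nc1cccc(Cc2c(C)c3ccc(OCCOc4no[n+]([O-])c4S(=O)(=O)c4ccccc4)cc3oc2=O)c1` carries 3-((methylsulfamoyl)amino)phenyl in place of 4-fluorophenyl on a saturated chain carbon bound to an aromatic carbon. Going by the values given here, the one measured step, a 1.2-fold higher number from compound 1 to compound 2 (0.08 log units; within the scatter), was only fluoro in place of hydrogen on an aromatic carbon, so it is a weak guide to this much bigger exchange. No step beyond the scatter is therefore expected in this assay, though with wide uncertainty in either direction. The expected change is a 1.4-fold lower number from compound 2 to compound 3 (0.15 log units; within the scatter). For compound 3 the estimated value is 2000 nM, within an expected range of 600 nM to 6000 nM.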

Compound 3, half-maximal inhibitory concentration: 3130 nM
Estimate against measurement, compound 3: 1.6-fold (0.19 log units) below, within the range that was stated.
By their numbers in this assay, from the lowest: compounds 1, 2 and 3 (each within the scatter of the next).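

In this assay the bigger 3-((methylsulfamoyl)amino)phenyl group, which brings hydrogen-bond donors and acceptors that 4-fluorophenyl lacks, gives a 1.1-fold higher number from compound 2 to compound 3 (0.04 log units; within the scatter) and, against the unsubstituted phenyl, a 1.3-fold higher number from compound 1 to compound 3 (0.12 log units; within the scatter). This place on a saturated chain carbon bound to an aromatic carbon therefore accepts far more than a single fluoro exchange, with no step beyond the scatter. Nothing available explains this flat result.

On these data alone, whether a carboxylic acid or an amine in this place would move the number beyond the scatter remains open.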